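A few compounds are considered here, and "the series" means these few. Any claim that something is new, unique, unknown or untested is made for them only; others in the source may bear on it.

Measured so far:
- compound 1, `S=C(N/N=C/c1cccs1)Nc1ccccc1`: > 100000 nM
- compound 2, `S=C(N/N=C/c1cccs1)Nc1cccnc1`: > 100000 nM

In a functional assay on PC-3 cells (Homo sapiens) for inhibition, read by sulforhodamine B assay, with a stated time of 48 h (a higher number here means a weaker inhibitor of growth, a lower number a stronger inhibitor of growth), compound 1 gives > 100000 nM, which is a limit of the assay and not a number. Compound 2 likewise gives > 100000 nM, again a limit rather than a number. Among the measured compounds shown here, compound 1 therefore stands at the limit of this assay, where both of the values obtained so far sit (the limit of > 100000 nM in this assay, at which 2 of the 2 values shown sit); no step between measured compounds can be stated, and neither compound can be placed relative to the other.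

Compound 3, `CCc1ccc(NC(=S)N/N=C/c2cccs2)cc1`, differs from compound 1 by ethyl in place of hydrogen on an aromatic carbon. For the measured compounds named here, only this pair of measured limits informs the expectation for compound 3.

With compound 1 at a limit > 100000 nM, no step beyond the scatter is expected in this assay, and the expected step of a number no higher from compound 1 to compound 3 (the limit leaves the size open) is taken as none. Compound 3 is accordingly estimated at 100000 nM in this assay, with a range from 30000 nM to 300000 nM, and a reported limit rather than a number is thought likely.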

Compound 3, concentration for 50% growth inhibition: > 100000 nM
Compound 3 gave a limit, no number; the forecaster's own chance of this, stated with the estimate: 70%; the middle value sits exactly at the limit.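

In this assay compound 3 gives > 100000 nM, a limit of the assay and not a number, so no step can be read between it and compound 1. All values shown stand at the same limit: the limit of > 100000 nM in this assay, at which 3 of the 3 values shown sit.

The compounds shown leave open whether ethyl in place of hydrogen on an aromatic carbon changes growth inhibition at all.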